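The compounds below may be only part of what the source reports. "The series", "measured", "known", "first", "only" and "open" are said of these compounds alone.

Compound 1 `CCCNNC(=O)c1ccc(CNC(=O)c2cc3cc(Cl)ccc3[nH]2)cc1` was tested in an assay on isolated protein for inhibition of protein deacetylase HDAC6 (Homo sapiens), read by fluorescence, with a stated time of 2 h; on this read-out higher numbers stand for weaker inhibition and lower numbers for stronger inhibition. In this assay compound 1 gives only a limit, > 10000 nM. Compound 2 `CCCNNC(=O)c1ccc(CNC(=O)c2cc3cc(Br)ccc3[nH]2)cc1` differs from compound 1 by bromo in place of chloro on an aromatic carbon. In this assay compound 2 likewise gives only a limit, > 10000 nM. The step that the two limits leave unreadable from compound 1 to compound 2 cannot be sized, since the limit of > 10000 nM in this assay, at which 3 of the 3 values shown sit, holds both values. Compound 3 `CCCNNC(=O)c1ccc(CNC(=O)c2cc3cc(Cl)ccc3o2)cc1` carries another core; the difference between the two cores is not broken down here. In this assay compound 3 again gives only a limit, > 10000 nM. Compound 4 `CCCNNC(=O)c1ccc(CNC(=O)c2cc3cc(Br)ccc3o2)cc1` is not yet measured; it differs from compound 3 by bromo in place of chloro on an aromatic carbon, the same change that separates compound 1 from compound 2. Because the limit of > 10000 nM in this assay, at which 3 of the 3 values shown sit, holds all three values, the step is expected to be a step that the limit leaves unreadable from compound 3 to compound 4. For compound 4 the expected value is 20000 nM, between 8000 nM and 100000 nM, most likely once more only a limit.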

Compound 4, half-maximal inhibitory concentration: > 10000 nM
Compound 4: a limit, no number; the forecaster's own chance of this, stated with the estimate: 85%; the middle value lies beyond the limit too.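

In this assay, among these compounds, compound 4 gives only a limit of > 10000 nM and so no step from compound 3 to compound 4 can be read, because all values stop at the same limit: the limit of > 10000 nM in this assay, at which 4 of the 4 values shown sit. Still open, from the compounds shown here alone, is how strongly any of these four compounds inhibits the enzyme, and whether bromo and chloro differ at all.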